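The source may hold more compounds than are shown below. What is called first, only, known or untested is meant among the compounds shown, and "the series" means these compounds.

Values measured in an ADME assay on the whole organism (Mus musculus, strain Swiss Webster) for pharmacokinetics, read by LC-MS, at a dose of 50 mg/kg by the oral route (a higher number here means more compound in the circulation at the dose given, a lower number less compound in the circulation), are as follows
- compound 1 `O=C(Nc1ccc(F)c(-c2nc3ncc(-c4ccc(F)cc4)cc3[nH]2)c1)N1CCCC1` gives 10200 ng.h/mL
- compound 2 `Cc1nc(C)c(C(=O)Nc2ccc(F)c(-c3nc4ncc(-c5ccccc5Cl)cn4n3)c2)o1` gives 309000 ng.h/mL
- compound 3 `O=C(Nc1ccc(F)c(-c2nc3ncc(-c4ccc(O)cc4)cc3[nH]2)c1)N1CCCC1` gives 137 ng.h/mL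

Among these three numbers compound 1 holds the middle place, with compound 2 higher and compound 3 lower. Compound 4 `O=C(Nc1ccc(F)c(-c2nc3ncc(-c4cc(F)cc(F)c4)cc3[nH]2)c1)N1CCCC1` departs from compound 1 in one place, where 3,5-difluorophenyl stands in place of 4-fluorophenyl on an aromatic carbon (3,5-difluorophenyl in place of 4-fluorophenyl on an aromatic carbon). Among the compounds with values here, only one measured step touches that group, and a 74-fold lower number from compound 1 to compound 3 (1.87 log units; beyond the scatter) came with hydroxy in place of fluoro on an aromatic carbon. Compound 4 brings in no hydroxy group, so the large size of a 74-fold lower number from compound 1 to compound 3 (1.87 log units; beyond the scatter) is not expected to carry over to it. Within the data shown here, no measured step exchanges one fluorinated phenyl for another, which leaves the estimate uncertain. No step beyond the scatter is expected in this assay in either direction. The expected step is a 1.0-fold lower number from compound 1 to compound 4 (0.01 log units; within the scatter) by this estimate. The estimate for compound 4 is 10000 ng.h/mL as the expected value, within an expected range from 3000 ng.h/mL to 35000 ng.h/mL in this account.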

Compound 4, area under the concentration-time curve: 9400 ng.h/mL
Compound 4: the middle estimate sits 1.1-fold (0.03 log units) above what was measured; the range from low to high includes it.
By their numbers in this assay, from the lowest: compound 3; then compounds 4 and 1 (each within the scatter of the next); then compound 2.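

In this assay, a 1.1-fold lower number from compound 1 to compound 4 (0.04 log units; within the scatter) shows that this position on the shared core accepts 3,5-difluorophenyl in place of 4-fluorophenyl with no step beyond the scatter, so moving from one fluorine to two at different ring carbons leaves the number in place. Alongside this, a 69-fold higher number from compound 3 to compound 4 (1.84 log units; beyond the scatter) sets 4-hydroxyphenyl apart from both fluorinated phenyl groups, and among these three compounds the large change at this position goes with the hydroxy group alone. Nothing shown here gives a reason for either step.

The compounds shown leave open how this position would respond to a phenyl ring carrying a methoxy group or an amine instead of fluorine. They also leave open whether 3,5-difluorophenyl would behave the same way on the core of compound 2.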